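This account rests on a few compounds, and the source may have more. Where it says the series, first, only, none or still open, it means among the compounds named here.

Measured compounds:

compound 1, `Cc1ccccc1C(=O)C#Cc1cn(COCCO)c(=O)[nH]c1=O`, 2200 nM
compound 2, `COc1ccc(C(=O)C#Cc2cnc(O)nc2O)cc1`, 2000 nM

In a functional assay on L1210 cells (Mus musculus) for cytotoxicity (a higher number here means a weaker inhibitor, a lower number a stronger inhibitor), compound 1 gives 2200 nM, and compound 2 gives 2000 nM; the two numbers lie within the usual scatter of each other, so compound 1 is not set apart from compound 2 by the data in hand.

Compound 3, `Cc1ccc(C(=O)C#Cc2cn(COCCO)c(=O)[nH]c2=O)cc1`, has yet to be measured in this assay. It differs from compound 1 in one place: 4-methylphenyl in place of 2-methylphenyl on a carbonyl carbon.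

Going by the values given here, no pair of measured compounds shows the effect of such a change, so there is no measured step to lean on. Compound 3 is therefore expected to give a number close to that of compound 1, with a step of a 1.1-fold lower number from compound 1 to compound 3 (0.04 log units; within the scatter) that may fall in either direction and is not expected to go beyond the scatter. The estimate for compound 3 in this assay is 2000 nM, with a range from 700 nM to 6000 nM.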

Compound 3, half-maximal inhibitory concentration: 900 nM
The estimate for compound 3 lay 2.2-fold (0.35 log units) above the measured number, within the range that was stated.
By their numbers in this assay, from the lowest: compound 3; then compounds 2 and 1 (each within the scatter of the next).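

In this assay, 4-methylphenyl in place of 2-methylphenyl on a carbonyl carbon gives a 2.4-fold lower number from compound 1 to compound 3 (0.39 log units; beyond the scatter), a modest step. Going by these compounds alone, the earlier compounds offered no pair that differed in one place, so this is the first measured sign that the number responds to a change at this position, even though the group that leaves and the group that enters have the same atoms, joined differently. Nothing in hand accounts for this step.

As far as these compounds go, with a single pair, it remains open what a 3-methylphenyl or unsubstituted phenyl group, or a phenyl ring carrying an amine or a carboxylic acid, would give on the same carbonyl carbon. From the compounds shown here alone, it is also open whether the step would recur on a core lacking the chain shared by compound 1 and compound 3.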